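The source may report more compounds than this note shows. Statements on the series, on what has been measured and on what is new or still open speak of the compounds shown alone.

Going by the values given here, compound 3 `O=C(/C=C\Nc1ccc(Cl)cc1)c1cn(-c2ccccc2)nc1-c1ccc(Cl)cc1` is the only compound here with an actual number in an ADME assay on HaCaT cells (Homo sapiens) for antiproliferative activity, read by MTT assay, with a stated time of 48 h (on this read-out higher numbers stand for weaker inhibition and lower numbers for stronger inhibition), where compound 3 gives 23400 nM. Compound 1 `O=C(/C=C\Nc1ccc(C(F)(F)F)cc1)c1cn(-c2ccccc2)nc1-c1ccccc1` reaches only a limit of this assay, and in this assay compound 1 gives > 50000 nM. Compound 2 `O=C(/C=C\Nc1ccc(C(F)(F)F)cc1)c1cn(-c2ccccc2)nc1-c1ccc(F)cc1` likewise reaches only a limit, and in this assay compound 2 gives > 50000 nM. Among the compounds with values here, the one step between measured compounds, a step that the two limits leave unreadable from compound 1 to compound 2, cannot be read in size, since both of its ends sit at the limit of > 50000 nM in this assay, at which 2 of the 3 values shown sit. Compound 4 `O=C(/C=C\Nc1ccc(C(F)(F)F)cc1)c1cn(-c2ccccc2)nc1-c1ccc(Cl)cc1` is not yet measured. It differs from compound 3 by trifluoromethyl in place of chloro on an aromatic carbon, that is, (4-chlorophenyl)amino becomes (4-(trifluoromethyl)phenyl)amino. Within the data shown here, no measured step shows this exact change, so the expectation rests on the fact that compound 1 and compound 2, which both carry the (4-(trifluoromethyl)phenyl)amino group, sit at the limit. Compound 4 is therefore expected to shift toward weaker inhibition, by a 1.9-fold higher number from compound 3 to compound 4 (0.28 log units; within the scatter), and may itself reach only a limit. The estimate for compound 4 in this assay is 45000 nM, within a range from 18000 nM to 110000 nM.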

Compound 4, half-maximal inhibitory concentration: > 50000 nM
Compound 4 was reported as a limit; the forecaster's own chance of this, stated with the estimate: 50%; at least 1.1-fold (0.04 log units) between middle value and limit.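

In this assay, going by these compounds alone, this is the first step at this position whose size can be read: changing (4-chlorophenyl)amino to (4-(trifluoromethyl)phenyl)amino gives an at least 2.1-fold higher number from compound 3 to compound 4 (0.32 log units; beyond the scatter). Compound 4 reaches only a limit, so the real size of the step could be larger than this minimum. Compound 1, compound 2 and compound 4 carry hydrogen, fluoro and chloro at the one place where they differ, yet the steps among them cannot be read, and all three keep the trifluoromethyl group and sit at the same limit: the limit of > 50000 nM in this assay, at which 3 of the 4 values shown sit.

Going by these compounds, what happens with a smaller or different group at this position, such as a methoxy group, an amine or a nitrile, stays open. So does whether the chloro group at the other site contributes to the number of compound 3.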